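Pyrazolone amides on HepG2: one limit and one open question

The source may hold more compounds than are shown below. What is called first, only, known or untested is meant among the compounds shown, and "the series" means these compounds.

Measured in a functional assay on HepG2 cells (Homo sapiens) for cytotoxicity, read by MTT assay, with a stated time of 72 h; a higher number here means a weaker inhibitor, a lower number a stronger inhibitor:
compound 1 `Cc1cc(=O)n(-c2cccc(F)c2)nc1C(=O)Nc1ccc(Oc2ncnc3[nH]ccc23)cc1`, 3180 nM
compound 2 `Cc1cc(=O)n(-c2ccc(Br)cc2F)nc1C(=O)Nc1ccc(Oc2ncnc3[nH]ccc23)cc1`, 3660 nM
compound 3 `Cc1cc(=O)n(-c2ccc(Br)cc2F)nc1C(=O)Nc1ccc(Oc2ncnc3c2ccn3C)c(F)c1`, a limit of the assay, > 60000 nM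

Compound 2 and compound 1 share a core and differ only by 3-fluorophenyl in place of 4-bromo-2-fluorophenyl on an aromatic nitrogen. That change gives a 1.2-fold lower number from compound 2 to compound 1 (0.06 log units; within the scatter), so the two values cannot be told apart. Compound 3 sits at the limit of > 60000 nM in this assay, at which 1 of the 3 values shown sits; how its core differs from that of compound 2 is not broken down here.

Compound 4 `Cc1cc(=O)n(-c2cccc(F)c2)nc1C(=O)Nc1ccc(Oc2ncnc3c2ccn3C)c(F)c1` has not yet been measured. It stands to compound 3 exactly as compound 1 stands to compound 2, the same change, (3-fluorophenyl in place of 4-bromo-2-fluorophenyl on an aromatic nitrogen). Because the earlier step, a 1.2-fold lower number from compound 2 to compound 1 (0.06 log units; within the scatter), was within the scatter, the step from compound 3 to compound 4 is expected to be of the same kind and size, a step that the limit leaves unreadable from compound 3 to compound 4. Since compound 3 itself gave only a limit, compound 4 is most likely expected to return a limit as well, with a value estimated around 70000 nM and a range from 30000 nM to 160000 nM in this assay.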

Compound 4, half-maximal inhibitory concentration: > 60000 nM
Compound 4: a limit, no number; the forecaster's own chance of this, stated with the estimate: 70%; the middle value is on the limit's open side.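

In this assay compound 4 gives > 60000 nM, which is a limit of the assay and not a number. Compound 3 also gave a limit, so no step between compound 3 and compound 4 can be read: the limit of > 60000 nM in this assay, at which 2 of the 4 values shown sit.

The compounds shown leave open how far beyond the limit compound 3 and compound 4 lie, and whether they differ at all.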